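Three Triterpenoid Triazole Esters and a Chlorophenyl Analogue

The source may report more compounds than this note shows. Statements on the series, on what has been measured and on what is new or still open speak of the compounds shown alone.

Compound 1 `C/C(=C\CC/C(C)=C/CC[C@@H]1[C@@]2(C)CCC(=O)C(C)(C)[C@H]2CC[C@@]1(C)O)CC/C=C(\C)C(=O)OCc1cn(-c2ccc(C(F)(F)F)cc2)nn1` gives > 150000 nM in an ADME assay on L132 cells (Homo sapiens) for cytotoxicity, read by MTT assay, with a stated time of 48 h (a lower number here means a stronger inhibitor, a higher number a weaker inhibitor), which is a limit of the assay and not a number.
Compound 2 `C/C(=C\CC/C(C)=C/CC[C@@H]1[C@@]2(C)CCC(=O)C(C)(C)[C@H]2CC[C@@]1(C)O)CC/C=C(\C)C(=O)OCc1cn(-c2ccccc2)nn1` gives > 150000 nM in this assay, again a limit.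
Compound 3 `C/C(=C\CC/C(C)=C/CC[C@@H]1[C@@]2(C)CCC(=O)C(C)(C)[C@H]2CC[C@@]1(C)O)CC/C=C(\C)C(=O)OCc1cn(-c2ccc([N+](=O)[O-])cc2)nn1` gives > 150000 nM in this assay, also a limit.

All three compounds share the same core and differ only in the group on the phenyl ring attached to the triazole nitrogen. Within the data shown here, since every value is a limit, no compound can be placed above or below another: compound 3 stands at the same limit as the other two, and nothing finer is known. The steps a step that the two limits leave unreadable from compound 1 to compound 2, a step that the two limits leave unreadable from compound 1 to compound 3 and a step that the two limits leave unreadable from compound 2 to compound 3 are therefore unreadable in size. Among the measured compounds shown here, the only evidence is the limit of > 150000 nM in this assay, at which 3 of the 3 values shown sit.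

Compound 4 `C/C(=C\CC/C(C)=C/CC[C@@H]1[C@@]2(C)CCC(=O)C(C)(C)[C@H]2CC[C@@]1(C)O)CC/C=C(\C)C(=O)OCc1cn(-c2cccc(Cl)c2)nn1` changes compound 3 by 3-chlorophenyl in place of 4-nitrophenyl on an aromatic nitrogen. No measured step can be read, so the expectation rests only on the fact that all three measured compounds sit at the limit; the step that the limit leaves unreadable from compound 3 to compound 4 is expected to stay within the scatter, with compound 4 most likely also reported at the limit. Compound 4 is estimated at 200000 nM, with a range from 100000 nM to 600000 nM.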

Compound 4, half-maximal inhibitory concentration: 94200 nM
Compound 4: the middle estimate sits 2.1-fold (0.33 log units) above what was measured, and the stated range ends above it.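

In this assay, among these compounds, compound 4 gives a measured number where the earlier compounds gave only limits, so the group on the aromatic nitrogen of the five-membered ring can bring a reading inside the range of the assay. The steps are an at least 1.5-fold lower number from compound 3 to compound 4 (0.20 log units; that floor lies within the scatter), an at least 1.5-fold lower number from compound 2 to compound 4 (0.20 log units; that floor lies within the scatter) and an at least 1.5-fold lower number from compound 1 to compound 4 (0.20 log units; that floor lies within the scatter); each is only a floor, so the true gaps could be larger, but the data do not show that they exceed the usual scatter. The steps among compound 1, compound 2 and compound 3 still cannot be read, and those three remain limits rather than numbers: the limit of > 150000 nM in this assay, at which 3 of the 4 values shown sit.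

The compounds shown leave open whether the reading of compound 4 comes from the chloro group itself or from its place on the phenyl ring. They also leave open how the reading would respond to an amine or a carboxylic acid on that ring, or to a longer chain between the ring and the triazole nitrogen.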